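Methoxyphenyl in Place of Methylphenyl on the Triazole Nitrogen

The source may hold more compounds than are shown below. What is called first, only, known or untested is meant among the compounds shown, and "the series" means these compounds.

Compound 1 `Cc1cccc(-n2nncc2CN2C(=O)C3(C(C#N)=C(N)Oc4c3c3nc5ccccc5nc3c3ccccc43)c3ccccc32)c1`: in a functional assay on HCT-116 cells (Homo sapiens) for antiproliferative activity, read by MTT assay, with a stated time of 48 h (on this read-out higher numbers stand for weaker inhibition and lower numbers for stronger inhibition), compound 1 gives > 50000 nM, which is a limit of the assay and not a number.
Compound 2 `N#CC1=C(N)Oc2c(c3nc4ccccc4nc3c3ccccc23)C12C(=O)N(Cc1cnnn1-c1ccc(F)cc1)c1ccccc12`: in this assay compound 2 gives > 50000 nM, again a limit.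
Compound 3 `Cc1ccccc1-n1nncc1CN1C(=O)C2(C(C#N)=C(N)Oc3c(N)cc4nc5ccccc5nc4c32)c2ccccc21`: in this assay compound 3 gives > 50000 nM, once more a limit.

Compound 3 thus stands only at a limit, and so do the other two measured compounds: all three values sit at the limit of > 50000 nM in this assay, at which 3 of the 3 values shown sit. Among the measured compounds shown here, no compound shows a readable number, so none can be called stronger or weaker than another.

Compound 4 `COc1ccc(-n2nncc2CN2C(=O)C3(C(C#N)=C(N)Oc4c(N)cc5nc6ccccc6nc5c43)c3ccccc32)cc1` differs from compound 3 in one place: 4-methoxyphenyl in place of 2-methylphenyl on an aromatic nitrogen. One measured step also exchanges the aryl group on the same aromatic nitrogen, namely a step that the two limits leave unreadable from compound 1 to compound 2; both ends of that step are limits, so its size cannot be read. No measured step shows any movement, and nothing among the shown values distinguishes one aryl group from another.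

The expectation for compound 4 is therefore that the step of a number no higher from compound 3 to compound 4 (the limit leaves the size open) stays within the scatter, with the value most likely again at the limit. Compound 4 is estimated at 50000 nM, with a range from 20000 nM to 150000 nM.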

Compound 4, half-maximal inhibitory concentration: > 50000 nM
Compound 4: only a limit was reported (the forecaster's own chance of this, stated with the estimate: 85%); the middle value lies on the limit itself.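

Compound 4, like compound 3, gives only a limit in this assay, so the exchange of 2-methylphenyl for 4-methoxyphenyl cannot be read as a step, and the values shown all rest at one point: the limit of > 50000 nM in this assay, at which 4 of the 4 values shown sit.

The compounds shown leave open whether the aryl group on the aromatic nitrogen changes antiproliferative activity at all.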